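Swapping the Piperazine Arm: Stability Outlook for Compound 3

The compounds below may be only part of what the source reports. "The series", "measured", "known", "first", "only" and "open" are said of these compounds alone.

Compound 1 `CN(C[C@H]1Cc2c(cccc2N2CCN(C3COC3)CC2)CN1)[C@H]1CCCc2cccnc21` and compound 2 `CC(C)N(C[C@H]1Cc2c(cccc2N2CCNCC2)CN1)[C@H]1CCCc2cccnc21` share a core. In an ADME assay on microsomes from liver (Mus musculus) for metabolic stability, read by LC-MS, with a stated time of 10 min (a higher number here means that more of the compound is left, a lower number that less of the compound is left), compound 1 gives 50.8%, the lowest of the two numbers shown. Compound 2 gives 91% in this assay, a result beyond the scatter above compound 1; the two compounds differ in more than one place, so this gap cannot be tied to a single change. Compound 3 `CN(C[C@H]1Cc2c(cccc2N2C[C@H]3C[C@@H]2CN3)CN1)[C@H]1CCCc2cccnc21` has not been measured. It differs from compound 1 in one place (a group of 7 heavy atoms (5 carbon, 2 nitrogen; 2 five-membered non-aromatic rings with 1 hetero atom each) in place of a group of 10 heavy atoms (7 carbon, 2 nitrogen, 1 oxygen; one four-membered non-aromatic ring with 1 hetero atom, one six-membered non-aromatic ring with 2 hetero atoms), on an aromatic carbon). Among the compounds with values here, with no single-change step known, only a small upward shift is expected, a number 9.2 percentage points higher from compound 1 to compound 3 (within the scatter), within the scatter. Compound 3 is expected to give 60%, between 35% and 85%.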

Compound 3, percent of the compound remaining: 95.9%
Compound 3: the middle estimate sits 35.9 percentage points below what was measured; the measured number lies above the stated range.
By their numbers in this assay, from the lowest: compound 1; then compounds 2 and 3 (each within the scatter of the next).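

In this assay, swapping the 4-(oxetan-3-yl)piperazin-1-yl group on the aromatic carbon for the bridged two-ring group gives a number 45.1 percentage points higher from compound 1 to compound 3 (beyond the scatter) as a single change. Within the data shown here, the earlier pair differed in more than one place, so only this step ties a large shift to this position. No measured data here explain the shift.

The oxetane and the piperazine ring leave together, so the compounds shown cannot separate their roles. From the compounds shown here alone, how a morpholine or a 4-methylpiperazin-1-yl group would read at this position also stays open.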